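Chloro on the ring of compound 1: an expectation

The source may hold more compounds than are shown below. What is called first, only, known or untested is meant among the compounds shown, and "the series" means these compounds.

Of the compounds shown here, three share one core and have been tested in a functional assay on the whole organism (strain Sprague-Dawley CD) for inhibition, with Rattus norvegicus as the target, read by paw edema, at a dose of 30 mg/kg by the intraperitoneal route; a higher number here means a stronger effect of the compound at the dose given, a lower number a weaker effect. Compound 1 `CCOC(=O)C(=O)Nc1cccccc1=O` gives 84%, the top figure of the three, though not separated from every neighbour. Compound 2 `CCOC(=O)C(=O)Nc1c(C)ccccc1=O` gives 47% in this assay, and compound 3 `CCOC(=O)C(=O)Nc1ccccc(NC)c1=O` gives 83% in this assay. Two steps start from compound 1: a number 37 percentage points lower from compound 1 to compound 2 (beyond the scatter), while a number 1 percentage points lower from compound 1 to compound 3 (within the scatter). Replacing a ring hydrogen thus either costs a great deal or costs nothing, depending on what enters.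

Compound 4 `CCOC(=O)C(=O)Nc1ccc(Cl)ccc1=O` has not yet been measured in this assay. It differs from compound 1 in one place: chloro in place of hydrogen on an aromatic carbon. Among the compounds with values here, both measured steps bear on it, since each swaps a hydrogen on an aromatic carbon for a small group, yet they disagree in size, and neither enters a chloro, so no step of the same kind exists. The prudent expectation is a loss smaller than that seen in compound 2, because a number 1 percentage points lower from compound 1 to compound 3 (within the scatter) shows the ring tolerating some substitution, while a number 37 percentage points lower from compound 1 to compound 2 (beyond the scatter) warns that it may not. Compound 4 is therefore estimated at 68%, in a range from 42% to 90%, meaning an expected step of a number 16 percentage points lower from compound 1 to compound 4 (beyond the scatter).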

Compound 4, a percentage reported as inhibition, in the whole organism at one dose (the size of the read-out at that dose, not a potency): 27%
The estimate for compound 4 lay 41 percentage points above the measured number; the measured number lies below the stated range.
By their numbers in this assay, from the lowest: compound 4; then compound 2; then compounds 3 and 1 (each within the scatter of the next).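

In this assay, chloro on this aromatic carbon, three ring bonds from the ring atom that bears the group of 8 heavy atoms, gives a number 57 percentage points lower from compound 1 to compound 4 (beyond the scatter), which removes most of the effect seen with compound 1 at the dose given. A single chlorine atom, with no hydrogen-bond donor or acceptor and no net charge, is thus enough to cause a large loss, and the tolerance shown by methylamino in compound 3 does not extend to this change at this place. Nothing available explains the drop.

The compounds shown leave open whether the loss belongs to chloro itself or to this carbon: they include no fluoro or methoxy group on this same carbon, and no chloro on another ring carbon, so group and place cannot yet be told apart. They also give the effect of compound 4 at a single dose only, which shows the size of the read-out at that dose and leaves its potency unresolved.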